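The source may report more compounds than this note shows. Statements on the series, on what has been measured and on what is new or still open speak of the compounds shown alone.

Among the measured compounds shown here, in a functional assay on RAW264.7 cells (Mus musculus) for inhibition, read by Griess assay, with a stated time of 24 h (a lower number here means a stronger inhibitor, a higher number a weaker inhibitor), compound 1 (`COc1cc(O)c(C(=O)/C=C/c2ccc(OCCCN3CCCC3)c(OC)c2)c(OC)c1`) gives 6500 nM and holds the highest of the three numbers measured so far, which makes it the weakest inhibitor of the set. Compound 3 (`COc1cccc(/C=C/C(=O)c2ccc(OC)cc2O)c1`) gives 3200 nM and compound 2 (`CCOc1cc(OC)cc(OC)c1C(=O)/C=C/c1cccc(OC)c1`) gives 2700 nM in this assay, and both numbers lie lower than that of compound 1 by more than the usual scatter. Neither of these two carries the 3-(pyrrolidin-1-yl)propoxy group.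

Compound 4 (`COc1cccc(/C=C/C(=O)c2c(O)cc(OC)cc2OC)c1`) has not yet been measured. The change from compound 1 (hydrogen in place of 3-(pyrrolidin-1-yl)propoxy on an aromatic carbon) puts hydrogen in place of 3-(pyrrolidin-1-yl)propoxy on an aromatic carbon, ortho to a methoxy group. For the measured compounds named here, no measured pair shows this change alone, so its size can only be judged from the three numbers. A modest drop in this assay seems likely, similar to the gaps that separate compound 1 from the other two compounds. The estimated step is small (a 2.3-fold lower number from compound 1 to compound 4 (0.37 log units; beyond the scatter)) and points toward stronger inhibition. Compound 4 is expected to give 2800 nM within a range of 1200 nM to 6500 nM when it is measured.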

Compound 4, half-maximal inhibitory concentration: 2400 nM
Compound 4: middle estimate off by 1.2-fold (0.07 log units), on the high side; low and high end bracket the measured number.
By their numbers in this assay, from the lowest: compounds 4, 2 and 3 (each within the scatter of the next); then compound 1.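

In this assay, among the compounds shown here, hydrogen in place of 3-(pyrrolidin-1-yl)propoxy gives a 2.7-fold lower number from compound 1 to compound 4 (0.43 log units; beyond the scatter), the first direct reading of this change on its own. On this aromatic carbon, then, the large group with its five-membered ring is not needed for inhibition, and the compound without it is the stronger inhibitor of this pair. Two changes elsewhere on the shared core stay within the scatter: methoxy in place of hydrogen on an aromatic carbon gives a 1.3-fold lower number from compound 3 to compound 4 (0.12 log units; within the scatter), and hydrogen in place of ethyl on an oxygen gives a 1.1-fold lower number from compound 2 to compound 4 (0.05 log units; within the scatter).

On these data alone, whether a shorter chain ending in dimethylamine, or a carboxylic acid, would be tolerated on this carbon remains open. No supporting measurement here explains why the number shifts with this change.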